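Swapping cyclopropyl for ethyl on the amine chain

This account rests on a few compounds, and the source may have more. Where it says the series, first, only, none or still open, it means among the compounds named here.

In a functional assay on MCF7 cells (Homo sapiens) for cytotoxicity, read by MTT assay, with a stated time of 24 h (on this read-out lower numbers stand for stronger inhibition and higher numbers for weaker inhibition), compound 3 (`O=C(Nc1ccc(C(F)(F)F)cc1)Nc1ccc(-c2ccnc(NCC3CC3)c2)c(C(F)(F)F)c1`) gives 15600 nM. That is level with compound 2 (`O=C(Nc1cccc(Cl)c1)Nc1ccc(-c2ccnc(NCC3CC3)c2)c(C(F)(F)F)c1`) at 17400 nM, and clearly higher than compound 1 (`CCNc1cc(-c2ccc(NC(=O)Nc3ccccc3Cl)cc2C(F)(F)F)ccn1`) at 3680 nM. Among the compounds with values here, the only measured step, a 1.1-fold lower number from compound 2 to compound 3 (0.05 log units; within the scatter), puts 4-(trifluoromethyl)phenyl in place of 3-chlorophenyl on an amide-type nitrogen. It therefore says nothing directly about the next change.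

Compound 4 (`CCCNc1cc(-c2ccc(NC(=O)Nc3ccc(C(F)(F)F)cc3)cc2C(F)(F)F)ccn1`) keeps that 4-(trifluoromethyl)phenyl but differs elsewhere: ethyl in place of cyclopropyl on a saturated chain carbon bound to a nitrogen on an aromatic ring. This is ethyl in place of cyclopropyl on a saturated chain carbon bound to a nitrogen on an aromatic ring, so cyclopropylmethyl becomes propyl. Within the data shown here, no measured step tests this swap, so only a small move is expected in this assay. The lower value of compound 1, 3680 nM, is a loose hint that any move would be downward, and it may well stay within the scatter. The estimated move is a 1.3-fold lower number from compound 3 to compound 4 (0.11 log units; within the scatter). For compound 4 the estimated value is 12000 nM, within a range from 5000 nM to 26000 nM.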

Compound 4, half-maximal inhibitory concentration: 7680 nM
Compound 4: the middle estimate sits 1.6-fold (0.19 log units) above what was measured; low and high end bracket the measured number.
By their numbers in this assay, from the lowest: compound 1; then compound 4; then compounds 3 and 2 (each within the scatter of the next).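

In this assay, replacing cyclopropylmethyl with propyl on the amine gives a 2.0-fold lower number from compound 3 to compound 4 (0.31 log units; beyond the scatter), so losing the three-membered ring changes the number by a modest but readable amount. Within the data shown here, this is the first measured sign that this amine chain affects the read-out, whereas the only earlier step, a 1.1-fold lower number from compound 2 to compound 3 (0.05 log units; within the scatter), changed the other end of the molecule and stayed within the scatter. Nothing measured here explains the drop from the loss of the ring.

One pair cannot show whether a longer chain such as butyl, or a chain ending in a hydroxyl group, would lower the number further than compound 4 does with 7680 nM. Going by these compounds, it also remains open whether the same swap would give a similar step with 3-chlorophenyl in place of 4-(trifluoromethyl)phenyl.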